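A few compounds are considered here, and "the series" means these few. Any claim that something is new, unique, unknown or untested is made for them only; others in the source may bear on it.

Compound 1 `CC#C[C@H]1CN(S(=O)(=O)c2ccc(N)nc2)CCN1c1ccc(C(O)(C(F)(F)F)C(F)(F)F)cn1`: 421 nM
Compound 2 `CC#C[C@H]1CN(S(=O)(=O)c2ccc(N)nc2)CCN1c1ccc(S(=N)(=O)C2CC2)cc1`: 208 nM

In an assay on cells (Hepatocyte) for inhibition of glucokinase regulatory protein (Mus musculus), with stated times of 20 min and 40 min (a lower number here means that less compound is needed, a higher number that more compound is needed for the effect), compound 2 gives 208 nM, the lowest of the two numbers shown. Compound 1 gives 421 nM in this assay, a gap beyond the usual scatter. Compound 3 `CC#C[C@H]1CN(S(=O)(=O)c2ccc(N)nc2)CCN1c1ccc(C(C)=O)cc1` is not yet measured; it differs from compound 2 in one place: a group of 3 heavy atoms (2 carbon, 1 oxygen; no ring) in place of a group of 6 heavy atoms (3 carbon, 1 nitrogen, 1 oxygen, 1 sulfur; one three-membered non-aromatic ring of carbon only), on an aromatic carbon. Among the compounds with values here, no step between two measured compounds differing in one place is available to lean on, so the expectation rests on the change alone. I expect compound 3 to need more compound than compound 2, a step of a 3.1-fold higher number from compound 2 to compound 3 (0.49 log units; beyond the scatter) that is probably beyond the scatter but not large. My estimate for compound 3 in this assay is 650 nM, with a range from 220 nM to 2000 nM.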

Compound 3, half-maximal effective concentration: > 12500 nM
Compound 3 was reported as a limit; the forecaster's own chance of this, stated with the estimate: 5%; middle value at least 19-fold (1.28 log units) from the limit.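

In this assay compound 3 gives > 12500 nM, which is a limit of the assay and not a number. Putting acetyl in place of the sulfur-bearing group, on an aromatic carbon para to a large group, is the first single change shown at this position, and it brings an at least 60-fold higher number from compound 2 to compound 3 (1.77 log units; beyond the scatter), so the group held here matters greatly. The true size of the step stays unknown, as one end of it is a limit: the limit of > 12500 nM in this assay, at which 1 of the 3 values shown sits.

Acetyl removes the three-membered ring, the sulfur and the nitrogen together, so the compounds shown cannot tell which of these counts. A cyclopropyl ketone or a methyl sulfone at this position would begin to separate them.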